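A few compounds are considered here, and "the series" means these few. Any claim that something is new, unique, unknown or untested is made for them only; others in the source may bear on it.

Of the compounds shown here, three built on one shared core have been tested in a functional assay on HL-60 cells (Homo sapiens) for inhibition, read by MTT assay, with a stated time of 72 h; a lower number here means a stronger inhibitor, a higher number a weaker inhibitor. Compound 1 `Cc1nc(-c2ccc(F)cc2)c(C(=O)N2CCN(c3cccc(Cl)c3)CC2)o1` gives 40.1 nM, compound 2 `Cc1nc(-c2ccccc2F)c(C(=O)N2CCN(c3cc(Cl)cc(Cl)c3)CC2)o1` gives 60.2 nM, and compound 3 `Cc1nc(-c2ccccc2)c(C(=O)N2CCN(c3ccccc3)CC2)o1` gives 39.1 nM. Compound 3 carries the lowest number of the three, yet its gaps to compound 1 and to compound 2 both fall within the usual scatter, so the three cannot be told apart. Compound 4 `Cc1ccc(C)c(N2CCN(C(=O)c3oc(C)nc3-c3ccccc3)CC2)c1` has not yet been measured. It differs from compound 3 in one place: 2,5-dimethylphenyl in place of phenyl on an amine nitrogen in a ring. Among the compounds with values here, no measured pair shows this change, so nothing sets the size of the step. The expected step is a 1.2-fold higher number from compound 3 to compound 4 (0.06 log units; within the scatter), small, of uncertain direction, and not beyond the scatter. Compound 4 is therefore expected to give about 45 nM, estimated between 18 nM and 120 nM.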

Compound 4, half-maximal inhibitory concentration: 31.3 nM
For compound 4 the middle estimate is 1.4-fold (0.16 log units) above the measured one; the measured number falls inside the stated range.
By their numbers in this assay, from the lowest: compounds 4, 3, 1 and 2 (each within the scatter of the next).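

Replacing phenyl with 2,5-dimethylphenyl on the ring nitrogen gives a 1.2-fold lower number from compound 3 to compound 4 (0.10 log units; within the scatter) in this assay and so stays within the scatter. At this position, then, a larger carbon-only aromatic group, with 8 heavy atoms in place of 6, is tolerated without a readable loss or gain. No measurement here explains this result.
The compounds shown leave open whether either methyl group matters on its own. They also leave open whether an amine or a carboxylic acid on this phenyl would shift the number beyond the scatter.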